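Aryl urea series: 2-methylphenyl in place of 4-methoxyphenyl

The source may hold more compounds than are shown below. What is called first, only, known or untested is meant among the compounds shown, and "the series" means these compounds.

Measured compounds:
compound 1 `CC1(C)CC(NC(=O)Nc2ccccc2)c2cc(F)ccc2O1` — a functional assay (aorta) with Rattus norvegicus as the target; a higher number here means that more compound is needed for the effect, a lower number that less compound is needed: 17100 nM
compound 2 `COc1cccc(NC(=O)NC2CC(C)(C)Oc3ccc(F)cc32)c1` — this assay: > 10000 nM, a limit of the assay and not a number
compound 3 `COc1ccc(NC(=O)NC2CC(C)(C)Oc3ccc(F)cc32)cc1` — this assay: 15500 nM

Compound 3 holds the lowest of the two numbers in this assay; its nearest neighbour is compound 1, with a 1.1-fold lower number from compound 1 to compound 3 (0.04 log units; within the scatter), so the two are not separated. Compound 2 stands at the assay limit (the limit of > 10000 nM in this assay, at which 1 of the 3 values shown sits). The steps involving it give no readable size: a step that the limit leaves unreadable from compound 1 to compound 2 and a step that the limit leaves unreadable from compound 2 to compound 3.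

Compound 4 `Cc1ccccc1NC(=O)NC1CC(C)(C)Oc2ccc(F)cc21` differs from compound 3 in one place: 2-methylphenyl in place of 4-methoxyphenyl on an amide-type nitrogen. Among the measured compounds shown here, no measured step exchanges a methoxy for a methyl on this ring or alters the substituent at the ring carbon named 2-methylphenyl. For the measured compounds named here, the steps that bear on the ring are methoxy added to the phenyl and one methoxyphenyl exchanged for the other; where readable, they stay within the scatter, and where not readable they set no size. The series as a whole sits at weak numbers. The expected step from compound 3 is therefore none beyond the scatter, estimated as a 1.0-fold lower number from compound 3 to compound 4 (0.01 log units; within the scatter). Compound 4 is estimated at 15000 nM, with a range of 5000 nM to 45000 nM.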

Compound 4, half-maximal effective concentration: > 30000 nM
Compound 4: no number, only a limit; the forecaster's own chance of this, stated with the estimate: 30%; middle value at least 2.0-fold (0.30 log units) from the limit.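

Compound 4 gives > 30000 nM in this assay, which is a limit of the assay and not a number: the limit of > 30000 nM in this assay, at which 1 of the 4 values shown sits. The 2-methylphenyl on the amide-type nitrogen brings no sign of a lower number to the series, and the two readable steps are an at least 1.9-fold higher number from compound 3 to compound 4 (0.28 log units; that floor lies within the scatter) and an at least 1.7-fold higher number from compound 1 to compound 4 (0.24 log units; that floor lies within the scatter), so neither floor separates compound 4 from the compound it is compared with. Among the compounds shown here, the step between compound 2 and compound 4 cannot be read, and with hydrogen, methoxy and methyl now carried on the phenyl, compound 1 and compound 3 hold the only numbers, while compound 2 and compound 4 stand at limits.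

Going by these compounds, the true size of the step to compound 4 remains open, and so does whether it belongs to the methyl itself or to its place on the ring, a question that a 4-methylphenyl or a 2-methoxyphenyl on the same nitrogen would address. Also open, on these data alone, is whether any group on this phenyl, such as an amine or a carboxylic acid, can move the series away from its weak numbers.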